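The source may report more compounds than this note shows. Statements on the series, on what has been measured and on what is new or still open speak of the compounds shown alone.

Measured compounds:
compound 1 `O=C(NCc1cc(Cl)ccc1-n1cnnn1)[C@@H]1CC=NN1C(=O)[C@H](O)c1ccccc1F` — 8.9 10^-6 cm/s
compound 2 `CC(C)(C)C[C@@H](O)C(=O)N1N=CC[C@H]1C(=O)NCc1cc(Cl)ccc1-n1cnnn1` — 24 10^-6 cm/s
compound 3 `CC(C)(C)C[C@@H](O)C(=O)N1[C@H](C(=O)NCc2cc(Cl)ccc2-n2cnnn2)C[C@@H]2C[C@@H]21` — 25 10^-6 cm/s

All three were run in an ADME assay on Caco-2 cells (Homo sapiens) for permeability, read by LC-MS, in the apical to basolateral direction, with a stated time of 60 min, at pH 6.5; on this read-out higher numbers stand for higher permeability and lower numbers for lower permeability. Compound 2 and compound 3 sit within the scatter of each other, and the difference between their two cores is not broken down here. For the measured compounds named here, the one counted step among the measured compounds is 2-fluorophenyl in place of neopentyl on a saturated chain carbon bound to a carbonyl carbon and an oxygen on a saturated carbon; it gave a 2.7-fold lower number from compound 2 to compound 1 (0.43 log units; beyond the scatter).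

Compound 4 `O=C(NCc1cc(Cl)ccc1-n1cnnn1)[C@@H]1C[C@@H]2C[C@@H]2N1C(=O)[C@H](O)c1ccccc1F` has not yet been measured in this assay. It is made from compound 3 by 2-fluorophenyl in place of neopentyl on a saturated chain carbon bound to a carbonyl carbon and an oxygen on a saturated carbon. This is the same kind of change as that from compound 2 to compound 1, and the place is described in identical words. Because compound 2 to compound 1 gave a 2.7-fold lower number from compound 2 to compound 1 (0.43 log units; beyond the scatter), and because compound 3 gives 25 10^-6 cm/s, a step of similar size is expected here; the estimated step is a 2.7-fold lower number from compound 3 to compound 4 (0.43 log units; beyond the scatter). The rest is a single precedent, so the expected range is kept wide. Compound 4 is estimated at 9.3 10^-6 cm/s in this assay, with an expected span from 5 10^-6 cm/s to 17 10^-6 cm/s.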

Compound 4, apparent permeability: 16 10^-6 cm/s
Compound 4: the middle estimate sits 1.7-fold (0.24 log units) below what was measured; the measured number falls inside the stated range.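

In this assay, 2-fluorophenyl in place of neopentyl gave a 1.6-fold lower number from compound 3 to compound 4 (0.19 log units; within the scatter), so on this core the step alone cannot be told apart from repeat measurement. Set beside the earlier step, the same change shows no difference between the two cores that this read-out can resolve: the same change on two cores in this assay, a 2.7-fold lower number (0.43 log units; beyond the scatter) from compound 2 to compound 1 and a 1.6-fold lower number (0.19 log units; within the scatter) from compound 3 to compound 4, 1.7-fold (0.24 log units) apart, within the scatter of two such steps. This supports carrying the size of the step from one of these cores to the other, but it rests on two cores only, with one step beyond the scatter and one within it, so it does not show that the change lowers the number on every core in the series or how large the step would be on a third.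

The compounds shown leave open how this place would respond to other groups, such as an unsubstituted phenyl, a cyclohexyl, or a chain carrying an amine or a carboxylic acid. They also leave open whether the agreement would hold once the shared benzyl amide part is changed.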